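Chloro in place of hydrogen on the shared dichloropurine core

This account rests on a few compounds, and the source may have more. Where it says the series, first, only, none or still open, it means among the compounds named here.

Measured compounds:
compound 1 `ClCc1cccc(Cn2cnc3nc(Cl)nc(Cl)c32)c1` gives 5010 nM in a functional assay on MOLT-4 cells (Homo sapiens) for cytotoxicity, read by sulforhodamine B assay, with a stated time of 48 h; a higher number here means that more compound is tolerated, a lower number that less compound is tolerated
compound 2 `ClCc1ccc(Cn2cnc3ncnc(Cl)c32)cc1` gives "not determined" (no result reported) in this assay

Compound 2 stands nowhere on the numbers: its entry in this assay reads "not determined" (no result reported), so it provides no anchor. Compound 3 `ClCc1ccc(Cn2cnc3nc(Cl)nc(Cl)c32)cc1` carries the change (chloro in place of hydrogen on an aromatic carbon). With no number for compound 2, the size and direction of the step to compound 3 cannot be anchored in this assay. The nearest measured neighbour is compound 1, whose value in this assay is 5010 nM. Compound 3 is therefore estimated at 5000 nM, expected between 1800 nM and 14000 nM.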

Compound 3, concentration lethal to 50% of the cells: > 100000 nM
Compound 3 was reported as a limit; the forecaster's own chance of this, stated with the estimate: 10%; middle value at least 20-fold (1.30 log units) from the limit.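

Compound 2 carries no number and compound 3 stands only as a limit, > 100000 nM, so no step can be read between them. The compounds shown leave open what chloro in place of hydrogen does to cytotoxicity.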